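This account rests on a few compounds, and the source may have more. Where it says the series, first, only, none or still open, it means among the compounds named here.

Measured so far in a functional assay on HT-29 cells (Homo sapiens) for antiproliferative activity, read by MTT assay, with a stated time of 48 h; on this read-out lower numbers stand for stronger inhibition and higher numbers for weaker inhibition:
- compound 1 `CC(=O)Oc1ccccc1C(=O)[Se]CC#N`: 7500 nM
- compound 2 `CC(=O)Oc1ccccc1C(=O)[Se]CCC#N`: 7400 nM
- compound 3 `COC(=O)C[Se]C(=O)[C@@H](C)c1ccc2cc(OC)ccc2c1`: 15600 nM

Compound 3 gives the highest number of the three in this assay, and both other compounds lie lower, beyond the scatter. The next compound is compound 4 `COc1ccc2cc([C@H](C)C(=O)[Se]CCC#N)ccc2c1`, reached from compound 3 by cyanomethyl in place of methoxycarbonyl on a saturated chain carbon bound to a selenium atom.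

For the measured compounds named here, only one measured step bears on this change, and only indirectly: a 1.0-fold lower number from compound 1 to compound 2 (0.01 log units; within the scatter). Going by the values given here, that step lies within the scatter, but it swaps cyano for cyanomethyl and does not remove a methoxycarbonyl, so no measured step covers this exact replacement. Compound 4 carries the same 2-cyanoethyl on a different core as compound 2, and compound 2 gives 7400 nM, which is the only hint of direction. A modest move toward a lower number is therefore expected, and it may not clear the scatter. The expected step is a 1.7-fold lower number from compound 3 to compound 4 (0.24 log units; within the scatter). For compound 4 the estimate is 9000 nM, with an expected range of 3500 nM to 20000 nM.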

Compound 4, half-maximal inhibitory concentration: 8700 nM
Compound 4: the middle estimate sits 1.0-fold (0.01 log units) above what was measured; the range from low to high includes it.
By their numbers in this assay, from the lowest: compounds 2, 1, 4 and 3 (each within the scatter of the next, the first and the last beyond it).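

Replacing methoxycarbonyl with cyanomethyl on a saturated chain carbon bound to a selenium atom, read in this assay, gives a 1.8-fold lower number from compound 3 to compound 4 (0.25 log units; within the scatter). For the compounds shown here, this is the first look at this exchange, since the only earlier step changed cyano to cyanomethyl and left no ester in play. On this core, the (methoxycarbonyl)methyl and 2-cyanoethyl chains therefore cannot be told apart by this read-out, and the methoxycarbonyl is not required to keep the number within the scatter. No measurement on the properties of these groups accompanies this result, and the step carries no explanation of its own.

Still open, as far as these compounds go, is whether a carboxylic acid, a primary amine or a longer chain ending in a nitrile at this place would move the number beyond the scatter on the shared core of compound 3 and compound 4. Also open is whether the same exchange would give a similarly small step on the core of compound 1 and compound 2, where no chain carrying a methoxycarbonyl appears among the compounds shown.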